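Swapping the ring on the thiocarbonyl carbon of compound 3

This account rests on a few compounds, and the source may have more. Where it says the series, first, only, none or still open, it means among the compounds named here.

Compound 1 `COc1ccc2occ(CSC(=S)N3CCCCC3)c(=O)c2c1`: 3500 nM
Compound 2 `O=c1cc(CSC(=S)N2CCN(c3ccccc3)CC2)oc2cc(Cl)ccc12`: 25900 nM
Compound 3 `CN1CCN(C(=S)SCc2coc3ccccc3c2=O)CC1`: 5900 nM

Of the compounds shown here, three have been tested in a functional assay on HeLa cells (Homo sapiens) for antiproliferative activity, read by MTT assay, with a stated time of 72 h; on this read-out higher numbers stand for weaker inhibition and lower numbers for stronger inhibition. Each carries the same core with a sulfur-linked thiocarbonyl group that ends in a nitrogen ring; they differ in that ring and in what sits on the core. In this assay compound 3 gives 5900 nM, the second highest of the three numbers. Its nearest neighbour is compound 1, which gives 3500 nM, a gap that lies within the usual scatter, so the two cannot be ranked against each other. Compound 2 stands furthest away at 25900 nM, a gap that lies beyond the scatter.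

Compound 4 `O=c1c(CSC(=S)N2CCCCC2)coc2ccccc12` has not yet been measured. It differs from compound 3 in one place: piperidin-1-yl in place of 4-methylpiperazin-1-yl on a thiocarbonyl carbon. Going by the values given here, the only measured compound that also carries piperidin-1-yl is compound 1, whose value of 3500 nM sits close to that of compound 3; the two, however, also differ on the core, so no direct step is known. Compound 4 is therefore expected to stay near compound 3, with a step of a 1.5-fold lower number from compound 3 to compound 4 (0.17 log units; within the scatter) of no more than the scatter. The estimate for compound 4 in this assay is 4000 nM, with a range from 1500 nM to 12000 nM.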

Compound 4, half-maximal inhibitory concentration: 2300 nM
For compound 4 the middle estimate is 1.7-fold (0.24 log units) above the measured one, and the stated range covers the measured number.
By their numbers in this assay, from the lowest: compounds 4, 1 and 3 (each within the scatter of the next, the first and the last beyond it); then compound 2.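

In this assay, going by these compounds alone, the change of 4-methylpiperazin-1-yl to piperidin-1-yl on a thiocarbonyl carbon gives a 2.6-fold lower number from compound 3 to compound 4 (0.41 log units; beyond the scatter), the one direct reading of this position so far, and it shows that the ring on this carbon can shift the number by more than the scatter, though the step is modest. The other single change, hydrogen in place of methoxy on an aromatic carbon, gives a 1.5-fold lower number from compound 1 to compound 4 (0.18 log units; within the scatter), so compound 1 and compound 4 cannot be ranked against each other, and the earlier closeness of compound 1 and compound 3 did not reveal the gap that compound 3 shows to compound 4 in this direct pair. No measurement of any property of these two rings is at hand to account for the ring step.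

As far as these compounds go, whether that step follows from the second ring nitrogen or from its methyl stays open, and a piperazin-1-yl ring without the methyl, or a morpholin-4-yl ring with an oxygen atom in the ring, would help to separate the two. From the compounds shown here alone, it is also open whether the same ring change gives a similar step on a core that carries methoxy.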